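The source may hold more compounds than are shown below. What is called first, only, known or untested is meant among the compounds shown, and "the series" means these compounds.

Measured so far:
compound 1 `Oc1c(Cc2ccccn2)ccc2ccccc12` — 390 nM
compound 2 `Cc1ccc(C)c2c(O)c(Cc3ccccc3)ccc12` — 120 nM

In an assay on RBL-1 cells with Polyunsaturated fatty acid 5-lipoxygenase (Rattus norvegicus) as the target (a higher number here means a weaker inhibitor, a lower number a stronger inhibitor), compound 1 gives 390 nM, the higher of the two numbers, while compound 2 gives 120 nM, a lower number separated from it by more than the usual scatter. Compound 3 `O=C(O)CCCCc1ccc2ccccc2c1O` differs from compound 1 in one place: 3-carboxypropyl in place of pyridin-2-yl on a saturated chain carbon bound to an aromatic carbon. Among the measured compounds shown here, no measured pair shows this kind of change, so its size is not known from these data. Compound 3 is expected to be somewhat weaker than compound 1, the step of a 2.6-fold higher number from compound 1 to compound 3 (0.41 log units; beyond the scatter) being estimated as beyond the scatter. The estimated value for compound 3 is 1000 nM, in a range from 250 nM to 4000 nM.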

Compound 3, half-maximal inhibitory concentration: 4200 nM
Estimate against measurement, compound 3: 4.2-fold (0.62 log units) below, outside the stated range (above it).
By their numbers in this assay, from the lowest: compound 2; then compound 1; then compound 3.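

In this assay, this position proves far from indifferent to what it carries: 3-carboxypropyl in place of pyridin-2-yl on a saturated chain carbon bound to an aromatic carbon gives an 11-fold higher number from compound 1 to compound 3 (1.03 log units; beyond the scatter). The two groups hold the same count of heavy atoms, and that equal count did not keep the numbers together. Nothing measured here bears on the reason for this step.

The compounds shown leave open whether the step follows the carboxylic acid or the loss of the ring. A methyl ester, an amide or a plain alkyl chain at this place could separate the two.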